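Sulfonyl aryl exchange in the piperazinyl guanidine series

This account rests on a few compounds, and the source may have more. Where it says the series, first, only, none or still open, it means among the compounds named here.

Three compounds of the series carry a measurement in a functional assay on HL-60 cells (Homo sapiens) for antiproliferative activity, read by MTT assay, with a stated time of 72 h; a higher number here means a weaker inhibitor, a lower number a stronger inhibitor. Compound 1 `CCn1cc(C(=O)O)c(=O)c2cc(F)c(N3CCN(C(=N)NS(=O)(=O)c4ccc(C)cc4)CC3)cc21` gives 43 nM in this assay. Compound 2 `N=C(NS(=O)(=O)c1ccc(Cl)cc1)N1CCN(c2cc3c(cc2F)c(=O)c(C(=O)O)cn3C2CC2)CC1` gives 43 nM, and compound 3 `CCn1cc(C(=O)O)c(=O)c2cc(F)c(N3CCN(C(=N)NS(=O)(=O)c4cccc(Cl)c4)CC3)cc21` gives 43 nM. Compound 1 thus stands level with compounds 2 and 3 at the digits shown; its nearest neighbour is compound 2 and its furthest compound 3, both within the usual scatter of the measurement.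

For the measured compounds named here, only one single-point step is measured so far: no change at the digits printed from compound 1 to compound 3 (within the scatter), which exchanges 4-methylphenyl for 3-chlorophenyl on a sulfonyl sulfur and leaves the reading unchanged within the scatter. Going by the values given here, compound 2 carries 4-chlorophenyl on its sulfonyl sulfur but differs from compound 1 in two places, so no step to it exists; its value and that of compound 1 simply coincide.

Compound 4 `CCn1cc(C(=O)O)c(=O)c2cc(F)c(N3CCN(C(=N)NS(=O)(=O)c4ccccc4Cl)CC3)cc21` is not yet measured. 2-chlorophenyl in place of 4-methylphenyl on a sulfonyl sulfur The change is of the same kind as the measured step, a chlorophenyl entering for 4-methylphenyl on a sulfonyl sulfur, and that step, no change at the digits printed from compound 1 to compound 3 (within the scatter), was flat. Compound 2 with its own chlorophenyl also sits at the same reading. No step beyond the scatter is therefore expected in this assay, and no change at the digits printed from compound 1 to compound 4 (within the scatter) is expected to be flat. Compound 4 is estimated at 43 nM, with a range of 20 nM to 95 nM.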

Compound 4, half-maximal inhibitory concentration: 43 nM
For compound 4 middle estimate and measured number coincide at the digits printed, within the range that was stated.
By their numbers in this assay, from the lowest: compounds 1, 2, 3 and 4 (each within the scatter of the next).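

In this assay the exchange of 4-methylphenyl for 2-chlorophenyl on a sulfonyl sulfur gives no change at the digits printed from compound 1 to compound 4 (within the scatter) and so repeats, with a second chlorophenyl, the flat result of the 3-chlorophenyl exchange. New here is a direct comparison of two chlorophenyl groups on the same sulfonyl sulfur with the rest of the molecule held constant: no change at the digits printed from compound 3 to compound 4 (within the scatter) shows that, in this pair, moving from 3-chlorophenyl to 2-chlorophenyl leaves the reading within the scatter. Compound 1, compound 3 and compound 4 thus place three different substituted phenyl groups on this sulfonyl sulfur without a step beyond the scatter, a statement that holds for these three compounds only.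

Going by these compounds, whether a methoxy or nitrile group on the phenyl ring, or a methyl or longer alkyl chain in place of the ring on the sulfonyl sulfur, would move the reading beyond the scatter remains open. No measurement of any property of these groups is at hand to account for the flat readings.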